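The compounds below may be only part of what the source reports. "The series", "measured", "known", "first", "only" and "open" are said of these compounds alone.

Measured so far in a functional assay on PC-3 cells (Homo sapiens) for antiproliferative activity, read by MTT assay, with a stated time of 48 h; on this read-out lower numbers stand for stronger inhibition and higher numbers for weaker inhibition:
- compound 1 `COc1ccc(CN(C(=O)CSc2nc3ccccc3s2)c2cc(OC)c(OC)c(OC)c2)cc1O`: 2110 nM
- compound 2 `COc1ccc(CN(C(=O)CSc2nc3c(C)cccc3s2)c2cc(OC)c(OC)c(OC)c2)cc1O`: 12300 nM

Going by the values given here, compound 1 holds the lower of the two numbers, and the gap to its only neighbour is beyond the scatter. Compound 3 `COc1ccc(CN(C(=O)CSc2nc3ccccc3s2)c2cc(OC)c(OC)c(OC)c2)cc1F` is unmeasured and differs from compound 1 by fluoro in place of hydroxy on an aromatic carbon. This is fluoro in place of hydroxy on an aromatic carbon, or 3-hydroxy-4-methoxyphenyl to 3-fluoro-4-methoxyphenyl.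

Among the compounds with values here, the only measured step, a 5.8-fold higher number from compound 1 to compound 2 (0.77 log units; beyond the scatter), is methyl in place of hydrogen on an aromatic carbon, at a different place in the structure. Within the data shown here, no measured compound tests the hydroxy group, so that step offers only a rough scale, and the direction is a tentative expectation. The expected step is a 1.9-fold higher number from compound 1 to compound 3 (0.28 log units; within the scatter), of modest size and toward a higher number in this assay. For compound 3 the estimate is 4000 nM, with an expected range of 1000 nM to 16000 nM.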

Compound 3, half-maximal inhibitory concentration: 20100 nM
Compound 3: the middle estimate sits 5.0-fold (0.70 log units) below what was measured, outside the stated range (above it).
By their numbers in this assay, from the lowest: compound 1; then compounds 2 and 3 (each within the scatter of the next).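

In this assay, going by these compounds alone, this is the first reading at the hydroxy position of the 3-hydroxy-4-methoxybenzyl group, and the position proves sensitive: a 9.5-fold higher number from compound 1 to compound 3 (0.98 log units; beyond the scatter). The change swaps a group counted with one hydrogen-bond donor and one acceptor for fluoro, which is counted with neither, so the hydroxy group of compound 1 cannot be replaced by fluoro without loss in this assay. Together with a 5.8-fold higher number from compound 1 to compound 2 (0.77 log units; beyond the scatter), it leaves compound 1 ahead of both single-place changes, made at two separate places on the structure, and nothing available explains the size of the loss.

Open, as far as these compounds go, is whether an amino group or plain hydrogen at this position would hold the number of compound 1. Also open, from the compounds shown here alone, is whether the fluoro step would carry over to the methyl-bearing core of compound 2.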